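From 2-fluorophenyl to 4-methylphenyl on the shared core

A few compounds are considered here, and "the series" means these few. Any claim that something is new, unique, unknown or untested is made for them only; others in the source may bear on it.

Of the compounds shown here, three have been measured in an ADME assay on cells (Macrophage, Homo sapiens) for cytotoxicity, read by MTT assay, with a stated time of 24 h; a higher number here means that more compound is tolerated, a lower number that less compound is tolerated. Compound 3 `CC(O)Cn1c([N+](=O)[O-])cnc1/C=C/c1ccccc1F` stands highest of the three at 1410 nM. Compound 1 `CC(O)Cn1c([N+](=O)[O-])cnc1/C=C/c1ccc(F)cc1` gives 420 nM and compound 2 `CC(O)Cn1c([N+](=O)[O-])cnc1/C=C/c1ccc([N+](=O)[O-])cc1` gives 410 nM, and each of these numbers lies clearly under that of compound 3.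

Compound 4 `Cc1ccc(/C=C/c2ncc([N+](=O)[O-])n2CC(C)O)cc1` has not yet been measured. It differs from compound 3 in one place: 4-methylphenyl in place of 2-fluorophenyl on a double-bonded chain carbon bound to a double-bonded chain carbon. This puts 4-methylphenyl in place of 2-fluorophenyl on a double-bonded chain carbon bound to a double-bonded chain carbon.

Going by the values given here, two measured steps bear on this change. Putting 2-fluorophenyl in place of 4-fluorophenyl gave a 3.4-fold higher number from compound 1 to compound 3 (0.53 log units; beyond the scatter), a modest step beyond the scatter. Putting nitro in place of fluoro on an aromatic carbon gave a 1.0-fold lower number from compound 1 to compound 2 (0.01 log units; within the scatter), which lies within the scatter. On that evidence, the 4-methylphenyl of compound 4 is expected to fall closer to compound 1 at 420 nM than to compound 3 at 1410 nM. Among the compounds with values here, no compound carrying methyl has been measured, so the expectation remains loose.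

The expected step is a 2.8-fold lower number from compound 3 to compound 4 (0.45 log units; beyond the scatter), a modest move downward. Compound 4 is estimated at 500 nM, with an expected range from 200 nM to 1200 nM.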

Compound 4, half-maximal cytotoxic concentration: 860 nM
Beside the measured number, compound 4's estimate is 1.7-fold (0.24 log units) below it; measured number inside the range.
By their numbers in this assay, from the lowest: compounds 2 and 1 (each within the scatter of the next); then compounds 4 and 3 (each within the scatter of the next).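

In this assay, the step of a 1.6-fold lower number from compound 3 to compound 4 (0.21 log units; within the scatter) leaves 4-methylphenyl and 2-fluorophenyl indistinguishable at this place on a double-bonded chain carbon bound to a double-bonded chain carbon, so compound 3 no longer stands alone at the top of the series. Methyl also separates from the two groups tried earlier on the same aromatic carbon, with modest steps of a 2.0-fold higher number from compound 1 to compound 4 (0.31 log units; beyond the scatter) and a 2.1-fold higher number from compound 2 to compound 4 (0.32 log units; beyond the scatter), whereas fluoro and nitro could not be told apart, at a 1.0-fold lower number from compound 1 to compound 2 (0.01 log units; within the scatter). No measurement available here accounts for these differences.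

The compounds shown leave open whether a longer chain such as ethyl, or an amine or a carboxylic acid, on that aromatic carbon would stay with methyl or fall back towards fluoro and nitro. They also leave open whether the separation of methyl from fluoro and nitro, which rests on just these compounds and on modest steps, would hold in any other cell type.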